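A few compounds are considered here, and "the series" means these few. Any claim that something is new, unique, unknown or untested is made for them only; others in the source may bear on it.

For the measured compounds named here, compound 2 `CC/C(=C(/c1ccc(/C=C/C(=O)O)cc1)c1ccc2[nH]ncc2c1)c1ccccc1` stands second highest of the three numbers so far in a functional assay on MCF7 cells (Homo sapiens) for cytotoxicity, read by CellTiter-Glo, with a stated time of 5 days (a higher number here means a weaker inhibitor, a lower number a stronger inhibitor), where compound 2 gives 7.2 nM. Compound 1 `C/C(=C(/c1ccc(/C=C/C(=O)O)cc1)c1ccc2[nH]ncc2c1)c1ccccc1` gives 40 nM in this assay, and compound 3 `O=C(O)/C=C/c1ccc(/C(=C(/CCF)c2ccccc2)c2ccc3[nH]ncc3c2)cc1` gives 2.1 nM. The measured steps of a 5.6-fold lower number from compound 1 to compound 2 (0.74 log units; beyond the scatter) and a 3.4-fold lower number from compound 2 to compound 3 (0.54 log units; beyond the scatter) both concern the saturated chain carbon. Compound 4 `CC/C(=C(/c1ccc(/C=C/C(=O)O)cc1)c1ccc2[nH]ncc2c1F)c1ccccc1` differs from compound 2 by fluoro in place of hydrogen on an aromatic carbon. Going by the values given here, no measured step alters the aromatic ring of the shared core, so those chain steps give no direct guide to this change. Compound 4 is therefore expected to show a step of a 1.0-fold lower number from compound 2 to compound 4 (0.01 log units; within the scatter) that stays within the usual scatter. Compound 4 is estimated at 7 nM, with a range from 2.5 nM to 20 nM.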

Compound 4, half-maximal inhibitory concentration: 3 nM
Compound 4: the middle estimate sits 2.3-fold (0.37 log units) above what was measured, within the range that was stated.
By their numbers in this assay, from the lowest: compounds 3 and 4 (each within the scatter of the next); then compound 2; then compound 1.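

In this assay the change from 1H-indazol-5-yl to 4-fluoro-1H-indazol-5-yl gives a 2.4-fold lower number from compound 2 to compound 4 (0.38 log units; beyond the scatter) and so shows that the aromatic ring of the shared core, not only the saturated chain carbon, can shift the number. Fluoro is tolerated on this aromatic carbon, ortho to a large group. Nothing measured here speaks to what lies behind this step. Still open, from the compounds shown here alone, is whether chloro or methyl on the same aromatic carbon would act like fluoro, and whether the step would carry over to the fluorine-bearing chain of compound 3.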